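Methylsulfanyl in place of hydrogen: expected cytotoxicity

The source may hold more compounds than are shown below. What is called first, only, known or untested is meant among the compounds shown, and "the series" means these compounds.

The series shares one core. Compound 1 is `CCCCCN1C(=O)C/C(=C\c2cccc(C(=O)Nc3ccc(C)cc3)c2)C1=O`, compound 2 is `O=C(Nc1ccccc1)c1cccc(/C=C2\CC(=O)N(c3ccccc3)C2=O)c1` and compound 3 is `Cc1ccc(N2C(=O)C/C(=C\c3cccc(C(=O)Nc4cccc(F)c4)c3)C2=O)cc1`. In an ADME assay on HCT-116 cells (Homo sapiens) for cytotoxicity, read by MTT assay, with a stated time of 72 h (on this read-out lower numbers stand for stronger inhibition and higher numbers for weaker inhibition), compound 1 gives only a limit, > 100000 nM. Compound 2 also returns only a limit in this assay, > 100000 nM. Compound 3 likewise gives a limit, > 100000 nM. Among the measured compounds shown here, compound 2 thus stands where every value shown stands, at the limit of > 100000 nM in this assay, at which 3 of the 3 values shown sit, and no measured step between compounds exists to lean on. Compound 4 is `CSc1cccc(NC(=O)c2cccc(/C=C3\CC(=O)N(c4ccccc4)C3=O)c2)c1`; it differs from compound 2 by methylsulfanyl in place of hydrogen on an aromatic carbon. No step beyond the scatter is expected, and a limit is the likeliest outcome. Compound 4 is estimated at 100000 nM, within 30000 nM to 300000 nM. The expected step, a number no higher from compound 2 to compound 4 (the limit leaves the size open), is thus within the scatter.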

Compound 4, half-maximal inhibitory concentration: 65200 nM
Compound 4: middle estimate off by 1.5-fold (0.19 log units), on the high side; the measured number falls inside the stated range.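

Methylsulfanyl in place of hydrogen, on the aromatic carbon meta to a large group, gives an at least 1.5-fold lower number from compound 2 to compound 4 (0.18 log units; that floor lies within the scatter). In this assay compound 4 gives 65200 nM, so this change yields a true number, although the size of the step remains undefined. The other compounds shown stay at the assay limit: the limit of > 100000 nM in this assay, at which 3 of the 4 values shown sit.

From the compounds shown here alone, whether methoxy, an amine or a carboxylic acid on this carbon would also give a number remains open. So does whether methylsulfanyl would do so on another carbon of the ring.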